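Adding a Methoxy Group to the Ring-Hydroxylated Diol

The source may hold more compounds than are shown below. What is called first, only, known or untested is meant among the compounds shown, and "the series" means these compounds.

Three diols built on the same chain have been measured in a functional assay on THP-1 cells (Homo sapiens) for antiproliferative activity, read by MTT assay, with a stated time of 48 h; a higher number here means a weaker inhibitor, a lower number a stronger inhibitor. Compound 1 `O[C@@H](CCc1ccccc1)C[C@@H](O)CCc1ccccc1` gives 99.8 ug/mL. Compound 2 `O[C@H](CCc1ccccc1)C[C@@H](O)CCc1ccccc1` gives 40.5 ug/mL; the step of a 2.5-fold lower number from compound 1 to compound 2 (0.39 log units; beyond the scatter) rests on the observation that (the fact that compounds 1 and 2 differ only in the configuration as drawn). Compound 3 `Oc1ccc(CC[C@@H](O)C[C@@H](O)CCc2ccccc2)cc1` gives 12.6 ug/mL, the lowest number of the three, so it is the strongest inhibitor here, with compound 2 next and compound 1 furthest away. The step of a 3.2-fold lower number from compound 2 to compound 3 (0.51 log units; beyond the scatter) shows that a hydroxy group on the aromatic ring brought a modest gain.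

Compound 4 `COc1cc(CC[C@@H](O)C[C@@H](O)CCc2ccccc2)ccc1O` has not yet been measured. It differs from compound 3 as follows: methoxy in place of hydrogen on an aromatic carbon, the new group sitting ortho to the hydroxy group already present. Among the measured compounds shown here, no measured step adds a methoxy group, so the only guide is the step from compound 2 to compound 3, which was modest, and the methoxy group carries no hydrogen-bond donor. A small change is therefore expected, most likely a slight drop in the number or none beyond the scatter. For compound 4 the expected value in this assay is 9 ug/mL, within 3 ug/mL to 25 ug/mL, which corresponds to the expected step of a 1.4-fold lower number from compound 3 to compound 4 (0.15 log units; within the scatter).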

Compound 4, half-maximal inhibitory concentration: 72.2 ug/mL
Estimate against measurement, compound 4: 8.0-fold (0.90 log units) below; the measured number lies above the stated range.
By their numbers in this assay, from the lowest: compound 3; then compounds 2, 4 and 1 (each within the scatter of the next, the first and the last beyond it).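

In this assay, the ring that carries the hydroxy group does not respond to every added group in the same direction. Among the compounds shown here, until now the only change on this ring was a gain in strength (a 3.2-fold lower number from compound 2 to compound 3 (0.51 log units; beyond the scatter)), whereas methoxy in place of hydrogen, ortho to that hydroxy group, makes compound 4 a weaker inhibitor than compound 3 (a 5.7-fold higher number from compound 3 to compound 4 (0.76 log units; beyond the scatter)), so this position is sensitive to what is placed on it, and a group of only two heavy atoms with no hydrogen-bond donor is enough to show that. The information available on these compounds concerns only their drawn configuration and offers no explanation for this loss.

From the compounds shown here alone, it remains open whether the loss belongs to the methoxy group itself or to its place on the ring, since every comparison here rests on this single change at this single position. A fluorine atom or an ethoxy group at the same position, or a methoxy group on the ring of compound 2, which has no hydroxy group, would help to separate these two readings.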